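A few compounds are considered here, and "the series" means these few. Any claim that something is new, unique, unknown or untested is made for them only; others in the source may bear on it.

Measured compounds:
compound 1 `CO/C(O)=C1\C(C)=NC(C)=C(C(=O)OCCCN2C(=O)c3ccccc3S2(=O)=O)C1c1cccc([N+](=O)[O-])c1`, 2.6 nM in a functional assay (aorta) with Oryctolagus cuniculus as the target; on this read-out higher numbers stand for weaker inhibition and lower numbers for stronger inhibition
compound 2 `CO/C(O)=C1\C(C)=NC(C)=C(C(=O)OCCCN2C(=O)c3ccccc3S2(=O)=O)C1c1ccccc1[N+](=O)[O-]`, 1.5 nM in this assay

Among the compounds with values here, only two compounds have numbers so far, and they sit within the scatter of each other: the step of a 1.7-fold lower number from compound 1 to compound 2 (0.24 log units; within the scatter), which swaps one nitrophenyl for another on the shared core, is too small to be read as a real change. Compound 2 therefore stands alongside compound 1, with no ranking possible between them.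

Compound 3 `CC1=NC(C)=C(C(=O)OCCCN2C(=O)c3ccccc3S2(=O)=O)C(c2ccccc2[N+](=O)[O-])/C1=C(\O)OCC1CCCO1` keeps the core of compound 2 and differs only at the ester side: oxolan-2-yl in place of hydrogen on a saturated chain carbon bound to an oxygen on an unsaturated carbon. Within the data shown here, none of the measured steps touches this part of the molecule; the one step known concerns the nitrophenyl ring, so nothing measured points in a direction for this change. The expectation is therefore a step of about a 1.7-fold higher number from compound 2 to compound 3 (0.22 log units; within the scatter), that is, no shift beyond the scatter. Compound 3 is estimated at 2.5 nM, with a range from 0.8 nM to 8 nM.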

Compound 3, half-maximal inhibitory concentration: 6.8 nM
Estimate against measurement, compound 3: 2.7-fold (0.43 log units) below; low and high end bracket the measured number.
By their numbers in this assay, from the lowest: compounds 2 and 1 (each within the scatter of the next); then compound 3.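

Within the data shown here, this is the first change on the ester side with a readable result. In this assay it gives a 4.5-fold higher number from compound 2 to compound 3 (0.66 log units; beyond the scatter), a modest move towards weaker inhibition, whereas the swap of one nitrophenyl for another stayed within the scatter. The position on a saturated chain carbon bound to an oxygen on an unsaturated carbon therefore responds to what is placed there, but no available evidence explains this response.

The compounds shown leave open whether a plain butyl chain would give a number like that of compound 2 or that of compound 3, and whether an amine such as a 2-(dimethylamino)ethyl group would shift it further. They also leave open whether (oxolan-2-yl)methoxy would produce a similar step on the 3-nitrophenyl compound 1.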